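The source may report more compounds than this note shows. Statements on the series, on what has been measured and on what is new or still open speak of the compounds shown alone.

Measured compounds in an ADME assay on HepG2 cells (Homo sapiens) for cytotoxicity; a lower number here means that less compound is needed, a higher number that more compound is needed for the effect:
Compound 1, `COc1cc(OC)cc(C(=O)NCCNC(=O)[C@H](CC(=O)NC(C)(C)C)NS(=O)(=O)c2ccc(C)cc2)c1`: a limit of the assay, > 11000 nM.
Compound 2, `Cc1ccc(S(=O)(=O)N[C@@H](CC(=O)NC(C)(C)C)C(=O)NCCNC(=O)c2ccc(F)c(F)c2)cc1`: a limit of the assay, > 11000 nM.
Compound 3, `Cc1ccc(S(=O)(=O)N[C@@H](CC(=O)NC(C)(C)C)C(=O)NCCNC(=O)c2cccc(C#N)c2)cc1`: a limit of the assay, > 11000 nM.

None of these three values is a number; each is a limit. Compound 3 therefore stands only at a limit, and the two other compounds stand at the same limit (the limit of > 11000 nM in this assay, at which 3 of the 3 values shown sit). Among the measured compounds shown here, the three steps among them, a step that the two limits leave unreadable from compound 1 to compound 2, a step that the two limits leave unreadable from compound 1 to compound 3 and a step that the two limits leave unreadable from compound 2 to compound 3, are all left unreadable by the two limits, so no step has a readable size in this assay.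

Compound 4, `C#Cc1cccc(C(=O)NCCNC(=O)[C@H](CC(=O)NC(C)(C)C)NS(=O)(=O)c2ccc(C)cc2)c1`, is not yet measured in this assay. It differs from compound 3 in one place: ethynyl in place of cyano on an aromatic carbon. For the measured compounds named here, no measured step involves an exchange of cyano for ethynyl, and no measured step carries a readable size at all. There is thus no basis for expecting a move beyond the scatter in either direction; the step expected is a step that the limit leaves unreadable from compound 3 to compound 4. Compound 4 is expected at 15000 nM, with a range from 6000 nM to 40000 nM, and most likely it will again be reported only as a limit in this assay.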

Compound 4, half-maximal effective concentration: > 11000 nM
Compound 4 gave a limit, no number; the forecaster's own chance of this, stated with the estimate: 85%; the middle value is on the limit's open side.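

Compound 4 also stands only at a limit in this assay, so its steps from compound 1, compound 2 and compound 3 cannot be read: the limit of > 11000 nM in this assay, at which 4 of the 4 values shown sit.

No compound shown has a numeric value, so it stays open how far any exchange on the aromatic ring shifts the half-maximal effective concentration.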